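A few compounds are considered here, and "the series" means these few. Any claim that something is new, unique, unknown or untested is made for them only; others in the source may bear on it.

Among the compounds with values here, compound 2 `O=C(O)c1cnc2cc(F)ccc2c1O` gives 10500000 nM in an assay on isolated protein with malate dehydrogenase, mitochondrial (Sus scrofa) as the target (a lower number here means a stronger inhibitor, a higher number a weaker inhibitor), the highest of the two numbers known, the only other being compound 1 `O=C(O)c1ccc2c(O)c(C(=O)O)cnc2c1` at 1070000 nM. Compound 3 `NC(=O)c1ccc2c(O)c(C(=O)O)cnc2c1` carries carbamoyl in place of fluoro on an aromatic carbon. Within the data shown here, the one measured step that bears on this place, a 9.8-fold higher number from compound 1 to compound 2 (0.99 log units; beyond the scatter), is modest but beyond the scatter. Carbamoyl shares features counted for carboxy rather than for fluoro, so compound 3 is expected to give a lower number than compound 2, by a 3.5-fold lower number from compound 2 to compound 3 (0.54 log units; beyond the scatter). Compound 3 is therefore estimated at 3000000 nM, within 800000 nM to 12000000 nM.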

Compound 3, half-maximal inhibitory concentration: 741000 nM
The estimate for compound 3 lay 4.0-fold (0.61 log units) above the measured number; the whole stated range lies above it.
By their numbers in this assay, from the lowest: compounds 3 and 1 (each within the scatter of the next); then compound 2.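

At this position on the six-membered aromatic ring of carbon only, carbamoyl gives a far lower number than fluoro in this assay (a 14-fold lower number from compound 2 to compound 3 (1.15 log units; beyond the scatter)), a large step. Carbamoyl and carboxy cannot be told apart here (a 1.4-fold lower number from compound 1 to compound 3 (0.16 log units; within the scatter)), so amino in place of hydroxy on the carbonyl carbon makes no difference beyond the scatter. Nothing shown accounts for these results. Still open, on these data alone, is whether a simple amine or a methyl ester here would match compound 1 and compound 3 or compound 2, and whether a methylamide would keep the level of compound 3.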